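This account rests on a few compounds, and the source may have more. Where it says the series, first, only, none or still open, it means among the compounds named here.

Measured in an assay on cells for inhibition of Ectonucleotide pyrophosphatase/phosphodiesterase family member 1 (Homo sapiens), with a stated time of 60 min, tested at 1 uM; on this read-out lower numbers stand for less inhibition and higher numbers for more inhibition at the one concentration tested (going by the name of the read-out):

compound 1 `COc1cc2nc(/C=C/c3ccccn3)nc(N3CCC(CCNS(N)(=O)=O)CC3)c2cc1OC` — 85%
compound 2 `COc1cc2nc(/C=C/c3cccnc3)nc(N3CCC(CCNS(N)(=O)=O)CC3)c2cc1OC` — 86%

Compound 2 stands level with compound 1 on these two numbers: the step of a number 1 percentage points higher from compound 1 to compound 2 (within the scatter) lies within the scatter, so neither of the two is to be ranked above the other, and both sit at a high degree of inhibition at the single concentration tested.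

Compound 3 `COc1cc2nc(/C=C/c3ccncc3)nc(N3CCC(CCNS(N)(=O)=O)CC3)c2cc1OC` has not yet been measured. It differs from compound 2 by pyridin-4-yl in place of pyridin-3-yl on a double-bonded chain carbon bound to a double-bonded chain carbon. Within the data shown here, the only measured step with a bearing on this is the move of the ring nitrogen from compound 1 to compound 2, which produced no shift beyond the scatter in this assay. Two compounds give no ground to expect a further move of the ring nitrogen to behave differently, but they also give no guarantee; the expectation is therefore a step of a number 2 percentage points lower from compound 2 to compound 3 (within the scatter), essentially none beyond the scatter, with the range widened to allow for the thin evidence.

Compound 3 is estimated at 84% in this assay, with a range from 70% to 94%.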

Compound 3, a percentage reported as inhibition, at one concentration (the size of the read-out at that concentration, not a potency): 79%
Compound 3: middle estimate off by 5 percentage points, on the high side; the measured number falls inside the stated range.
By their numbers in this assay, from the lowest: compounds 3, 1 and 2 (each within the scatter of the next).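

In this assay, the pyridin-4-yl group completes the set of three pyridine attachments on the double-bonded chain carbon, and both new comparisons, a number 7 percentage points lower from compound 2 to compound 3 (within the scatter) and a number 6 percentage points lower from compound 1 to compound 3 (within the scatter), stay within the usual scatter. The numbers for all three placements of the ring nitrogen therefore stand level in this read-out, and the exchange of pyridin-3-yl or pyridin-2-yl for pyridin-4-yl gives no ground for ranking the three compounds. No measured data accompany these numbers that could say anything about their origin.

The compounds shown leave open whether the ring nitrogen is needed at all, since a plain phenyl ring at this place, or a phenyl ring carrying a carboxylic acid or an amine, would test that directly. They also leave open whether the three compounds would separate in potency, as a percentage at a single concentration cannot show that and a full concentration series would be needed to settle it.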